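A few compounds are considered here, and "the series" means these few. Any claim that something is new, unique, unknown or untested is made for them only; others in the source may bear on it.

Compound 1 `N#Cc1ccccc1N1CCN(Cc2nc3ccccc3[nH]2)CC1` and compound 2 `Fc1ccccc1N1CCN(Cc2nc3ccccc3[nH]2)CC1` share one core and differ only in the substituent on the six-membered aromatic ring of carbon only: cyano in compound 1, fluoro in compound 2. In an assay on HEK293 cells with D(4) dopamine receptor (Homo sapiens) as the target, read by FLIPR (a higher number here means that more compound is needed for the effect, a lower number that less compound is needed), compound 1 gives 14.6 nM. In this assay compound 2 gives 14.7 nM. Within the data shown here, the single measured step, a 1.0-fold higher number from compound 1 to compound 2 (0.00 log units; within the scatter), leaves the two numbers inside the scatter of each other, so on the values so far compound 2 is not separated from compound 1 in either direction.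

Compound 3 `CCOc1ccccc1N1CCN(Cc2nc3ccccc3[nH]2)CC1` is the next member; the change is ethoxy in place of fluoro on an aromatic carbon. Among the measured compounds shown here, no measured step involves an ethoxy group, so the one step at hand bears on it only indirectly, showing that exchanging cyano for fluoro at this position left the number where it was. The expected step in this assay is therefore small, a 1.0-fold higher number from compound 2 to compound 3 (0.01 log units; within the scatter), with no firm direction. Compound 3 is estimated at 15 nM, within a range of 5 nM to 50 nM.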

Compound 3, half-maximal effective concentration: 25 nM
The estimate for compound 3 lay 1.7-fold (0.22 log units) below the measured number; the measured number falls inside the stated range.
By their numbers in this assay, from the lowest: compounds 1, 2 and 3 (each within the scatter of the next).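

Ethoxy enters with 3 heavy atoms against 1 for fluoro, and with 1 hydrogen-bond acceptor against 0, yet this assay gives a 1.7-fold higher number from compound 2 to compound 3 (0.23 log units; within the scatter) and also a 1.7-fold higher number from compound 1 to compound 3 (0.23 log units; within the scatter) with both steps within the scatter. On an aromatic carbon ortho to a large group, an oxygen-linked chain therefore gives no step beyond the scatter, which the exchange of cyano for fluoro alone could not show. Nothing at hand explains this result.

The compounds shown leave open whether a longer chain such as butoxy, an amine or a carboxylic acid at this place would give a step beyond the scatter. They also leave open whether ethoxy would read the same on another carbon of this ring.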